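Notes on the triazole series: phenoxy in place of nitro

The source may report more compounds than this note shows. Statements on the series, on what has been measured and on what is new or still open speak of the compounds shown alone.

Measured so far:
Compound 1, `O=C(N1CCC=C[C@@H]1COCc1ccccc1)n1cc(-c2ccc(-c3ccccc3)cc2)nn1`, gives 12.6 nM in an assay on HEK293 cells for inhibition of Monoacylglycerol lipase ABHD6 (Homo sapiens), read by fluorescence; on this read-out lower numbers stand for stronger inhibition and higher numbers for weaker inhibition.
Compound 2, `O=C(N1CC=C[C@@H](O)[C@H]1COCc1ccccc1)n1cc(-c2ccc(-c3ccccc3)cc2)nn1`, gives 251 nM in this assay.
Compound 3, `O=C(N1CCC=C[C@@H]1COCc1ccccc1)n1cc(-c2ccc([N+](=O)[O-])cc2)nn1`, gives 31.6 nM in this assay.

Compound 3 stands second highest of the three numbers; its nearest neighbour is compound 1, whose number is lower, while compound 2 gives the highest number of the set. Going by the values given here, the only single-point step measured is a 2.5-fold higher number from compound 1 to compound 3 (0.40 log units; beyond the scatter), where nitro took the place of phenyl on the aromatic carbon and the number rose modestly. Among the compounds with values here, no step between compound 2 and compound 3 is measured; their values simply show compound 2 higher.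

Compound 4, `O=C(N1CCC=C[C@@H]1COCc1ccccc1)n1cc(-c2ccc(Oc3ccccc3)cc2)nn1`, differs from compound 3 by phenoxy in place of nitro on an aromatic carbon. Within the data shown here, the one step that bears on this is a 2.5-fold higher number from compound 1 to compound 3 (0.40 log units; beyond the scatter): removing the aromatic ring at that place raised the number, and compound 4 puts a six-membered aromatic ring back there through an oxygen. A reversal of that step, a modest fall in the number, is therefore expected, with compound 1 as the reference point. The expected step is a 2.0-fold lower number from compound 3 to compound 4 (0.30 log units; within the scatter). For compound 4 the estimate is 16 nM, within 5 nM to 50 nM.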

Compound 4, half-maximal inhibitory concentration: 6.31 nM
Beside the measured number, compound 4's estimate is 2.5-fold (0.40 log units) above it, within the range that was stated.
By their numbers in this assay, from the lowest: compounds 4 and 1 (each within the scatter of the next); then compound 3; then compound 2.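

In this assay, the aromatic carbon para to a large group separates phenoxy from nitro, with a 5.0-fold lower number from compound 3 to compound 4 (0.70 log units; beyond the scatter). Phenoxy and phenyl cannot be told apart at this place, as a 2.0-fold lower number from compound 1 to compound 4 (0.30 log units; within the scatter) lies within the scatter, so inserting the oxygen between the two aromatic rings leaves no readable change. Among the three groups shown here, the two carrying a six-membered aromatic ring of carbon only give the lower numbers, but nothing at hand explains this.

As far as these compounds go, it remains open whether a ring is needed at this place at all, or whether a butyl chain, an amine or a carboxylic acid would sit with phenyl and phenoxy or with nitro. Also open, from the compounds shown here alone, is how phenoxy would read on the core of compound 2.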